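Removing the second methyl from the dimethyl core of compound 3

The source may hold more compounds than are shown below. What is called first, only, known or untested is meant among the compounds shown, and "the series" means these compounds.

Measured compounds in a functional assay on MDA-N cells (Homo sapiens) for antiproliferative activity; a lower number here means a stronger inhibitor of growth, a higher number a weaker inhibitor of growth:
compound 1, `Cc1ccc2c(O)cc(-c3cccc(Cl)c3)nc2n1`: > 100000 nM
compound 2, `Cc1ccnc2nc(-c3cccc4ccccc34)cc(O)c12`: < 10 nM
compound 3, `Cc1cc(C)c2c(O)cc(-c3cccc4ccccc34)nc2n1`: 234 nM

Among the measured compounds shown here, compound 3 is the only member of the set that returns a number in this assay; the other two values are limits. For compound 2 the value < 10 nM is a limit of the assay (the limit of < 10 nM in this assay, at which 1 of the 3 values shown sits). For compound 1 the value > 100000 nM is likewise a limit (the limit of > 100000 nM in this assay, at which 1 of the 3 values shown sits). Among the numbers, compound 3 therefore stands alone.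

The next compound, compound 4, `Cc1ccc2c(O)cc(-c3cccc4ccccc34)nc2n1`, is made from compound 3 by hydrogen in place of methyl on an aromatic carbon. For the measured compounds named here, the only measured step, an at least 23-fold higher number from compound 2 to compound 3 (1.36 log units; beyond the scatter), concerns a methyl put onto another aromatic carbon of the same core and was large. Going by the values given here, the methyl that leaves in compound 4 is the one compound 2 carries, so the measured step does not directly cover this change; compound 4 keeps the methyl whose addition coincided with the large loss. Compound 2 and compound 4 differ only in which methyl remains, and compound 2 gives a limit while compound 4 is unmeasured. A moderate change in this assay is expected, most likely toward a higher number: for compound 4 the estimate is 450 nM, within 80 nM to 2500 nM, corresponding to an expected step of a 1.9-fold higher number from compound 3 to compound 4 (0.28 log units; within the scatter).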

Compound 4, concentration for 50% growth inhibition: < 10 nM
Compound 4: no number, only a limit; the forecaster's own chance of this, stated with the estimate: 5%; middle value at least 45-fold (1.65 log units) away from the limit.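

Hydrogen in place of methyl on this aromatic carbon, opposite the ring nitrogen, gives an at least 23-fold lower number from compound 3 to compound 4 (1.36 log units; beyond the scatter) in this assay, so this position also responds strongly to a single methyl. Read with an at least 23-fold higher number from compound 2 to compound 3 (1.36 log units; beyond the scatter), the result places the higher number of compound 3 with the presence of both methyl groups together: within these three compounds, taking away either methyl from compound 3 returns the series to the limit. The value of compound 4 is a limit and not a number, so the step gives only a minimum size, and the same holds for the step involving compound 2: the limit of < 10 nM in this assay, at which 2 of the 4 values shown sit.

Compound 2 and compound 4 both stand at that limit, so any ranking of the two remaining methyl positions cannot be read, and the series needs a value below the limit to separate them. Also open, going by these compounds, is how this carbon responds to an ethyl group, a methoxy group or an amine in place of the methyl, and whether the naphthyl-bearing compounds would keep their behaviour with the chlorophenyl group of compound 1, whose value is a limit.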